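The source may hold more compounds than are shown below. What is called first, only, known or untested is meant among the compounds shown, and "the series" means these compounds.

Working notes on the series. Compound 1 `OCCOCn1cnc2c(O)ncnc21` and compound 2 `Nc1nc2c(nc(Br)n2COCCO)c(=O)[nH]1` share a core bearing the (2-hydroxyethoxy)methyl group, and compound 3 `Nc1nc2c(nc(N)n2COCCO)c(=O)[nH]1` is the third member. Readings come from a functional assay on L1210 cells (Mus musculus) for inhibition; on this read-out lower numbers stand for stronger inhibition and higher numbers for weaker inhibition. In this assay compound 1 gives > 1000 ug/mL, which is a limit of the assay and not a number. In this assay compound 2 gives > 500 ug/mL, again only a limit. Among the compounds with values here, compound 2 therefore stands at a limit among the values shown, with no measured step to set it against, and the two limits the limit of > 1000 ug/mL in this assay, at which 1 of the 2 values shown sits, and the limit of > 500 ug/mL in this assay, at which 1 of the 2 values shown sits, are all that has been recorded so far. Compound 3 differs from compound 2 by amino in place of bromo on an aromatic carbon. Within the data shown here, no measured step covers a change of this kind, so the step expected in this assay is a step that the limit leaves unreadable from compound 2 to compound 3, none beyond the scatter, with the reading most likely again a limit. For compound 3 the estimate is 600 ug/mL, with a range from 200 ug/mL to 2000 ug/mL.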

Compound 3, concentration for 50% inhibition: 500 ug/mL
Compound 3: middle estimate off by 1.2-fold (0.08 log units), on the high side; low and high end bracket the measured number.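

In this assay, within the data shown here, compound 3 gives 500 ug/mL, the first actual number rather than a limit, so a substituent on this aromatic carbon, between two ring nitrogen atoms, can leave a value that can be read. The change of bromo to amino gives a number no higher from compound 2 to compound 3 (the limit leaves the size open). Its size cannot be read because the value of compound 2 is only a limit: the limit of > 500 ug/mL in this assay, at which 1 of the 3 values shown sits.

Going by these compounds, whether amino in place of bromo changes inhibition at all therefore stays open, and so does how a methylamino group or a chlorine atom on this carbon would read. Also open, on these data alone, is how a longer chain would read in place of the (2-hydroxyethoxy)methyl group.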